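Two Chlorines and a Hydroxymethyl on the Aniline Ring

This account rests on a few compounds, and the source may have more. Where it says the series, first, only, none or still open, it means among the compounds named here.

Measured compounds:
compound 1, `FC(F)(F)c1ccc(Nc2ncnc3c2CCN(c2ncccc2C(F)(F)F)C3)cc1`: 71 nM
compound 2, `FC(F)(F)c1ccc(Nc2ncnc3sc(Nc4ccccc4Cl)nc23)cc1`: 32 nM

In a functional assay on HEK293 cells for antagonist activity at transient receptor potential cation channel subfamily V member 1 (Rattus norvegicus), read by calcium flux (on this read-out lower numbers stand for stronger inhibition and higher numbers for weaker inhibition), compound 2 gives 32 nM, the lowest of the two numbers in hand. Among the compounds with values here, compound 1, the only other measured compound, gives 71 nM in this assay, a number above that of compound 2 by a margin beyond the usual scatter; the two share the aryl amine on one side but differ in their cores, so the gap cannot be tied to a single change.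

Compound 3, `OCc1cc(Cl)c(Nc2nc3c(Nc4ccc(C(F)(F)F)cc4)ncnc3s2)c(Cl)c1`, keeps the core of compound 2 and alters only the aryl group on the amine: 2,6-dichloro-4-(hydroxymethyl)phenyl in place of 2-chlorophenyl on a nitrogen on an aromatic ring. Within the data shown here, no measured pair shows this change, so no step for it can be read from the numbers.

Against that background, the step of a 1.6-fold lower number from compound 2 to compound 3 (0.20 log units; within the scatter) is expected to be small, within the scatter or a little downward, since compound 2 already gives 32 nM. Compound 3 is estimated to give 20 nM in this assay, within a range from 6 nM to 80 nM.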

Compound 3, half-maximal inhibitory concentration: 0.5 nM
The estimate for compound 3 lay 40-fold (1.60 log units) above the measured number; measured number below the stated range.
By their numbers in this assay, from the lowest: compound 3; then compound 2; then compound 1.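

With the core held fixed, putting 2,6-dichloro-4-(hydroxymethyl)phenyl in place of 2-chlorophenyl on a nitrogen on an aromatic ring gives a 64-fold lower number from compound 2 to compound 3 (1.81 log units; beyond the scatter) in this assay. Within the data shown here, this is the first comparison that differs in one place, and it shows that the number responds very strongly to the aryl group on this amine, something the earlier pair could not show with its differing cores. The incoming group brings a second chlorine and a hydroxymethyl, with one hydrogen-bond donor and one hydrogen-bond acceptor that the outgoing group lacks, but nothing available here bears on why the number fell so far.

The two additions arrive together, so the compounds shown leave open how much of the step belongs to the second chlorine and how much to the hydroxymethyl. Also open, from the compounds shown here alone, is whether a step of this size would survive if an amine, a carboxylic acid or a longer chain such as hydroxyethyl stood in place of the hydroxymethyl.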